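One Methyl Fewer on a Side-Chain Amine

The source may hold more compounds than are shown below. What is called first, only, known or untested is meant among the compounds shown, and "the series" means these compounds.

In a functional assay on HCT-116 cells (Homo sapiens) for cytotoxicity, read by MTT assay, with a stated time of 72 h (a higher number here means a weaker inhibitor, a lower number a stronger inhibitor), compound 2 (`CN(C)CCCNc1c(C(=O)NCc2ccc(F)cc2)nc(Br)c2cccnc12`) gives > 10000 nM as its reading, which is a limit and not a number. Compound 1 (`N[C@H]1CC[C@H](Nc2c(C(=O)NCc3ccc(F)cc3)nc(N3CCCCS3(=O)=O)c3cccnc23)CC1`) gives > 10000 nM as its reading, and that too is a limit. Compound 3 (`C[C@@H](CO)Nc1nc(C(=O)NCc2ccc(F)cc2)c(O)c2ncccc12`) has the entry "not determined" (no result reported) and so offers no comparison. Within the data shown here, compound 2 therefore stands at the limit of > 10000 nM in this assay, at which 2 of the 3 values shown sit, and no measured compound here carries an actual number.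

Compound 4 (`CNCCCNc1c(C(=O)NCc2ccc(F)cc2)nc(Br)c2cccnc12`) differs from compound 2 in one place, on an amine nitrogen whose other neighbours are saturated chain carbons, with hydrogen in place of methyl (hydrogen in place of methyl on an amine nitrogen). Dimethylamino thus becomes methylamino, and the rest of the molecule stays the same.

Among the measured compounds shown here, no pair of measured compounds shows what this change does on its own in this assay so any forecast has little to stand on. The expectation rests on compound 2 with > 10000 nM as its limit, and on how small the change is. No step beyond the usual scatter is expected in either direction, and the estimated change (a step that the limit leaves unreadable from compound 2 to compound 4) is correspondingly small. Compound 4 is estimated at 12000 nM with a range from 5000 nM to 30000 nM. Once it is tested, the outcome may well be only a limit.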

Compound 4, half-maximal inhibitory concentration: > 10000 nM
Compound 4: no number, only a limit; the forecaster's own chance of this, stated with the estimate: 75%; the middle value lies beyond the limit too.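

Compound 2 and compound 4 both end at a limit and not at a number, so no step between them can be read: the limit of > 10000 nM in this assay, at which 3 of the 4 values shown sit.

The compounds shown leave open what hydrogen in place of methyl on this amine nitrogen does in this assay, and none of them yet gives an actual number to compare.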